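The compounds below may be only part of what the source reports. "The series", "measured", "known", "first", "only" and "open" are said of these compounds alone.

Three compounds from this series have numbers in a functional assay on Jurkat cells for inhibition of nuclear factor NF-kappa-B complex (Homo sapiens) (a higher number here means a weaker inhibitor, a lower number a stronger inhibitor), so far. Compound 1 `CCOC(=O)c1cnc(CC)nc1NN1C(=O)C=C(C)C1=O` gives 10000 nM in this assay. Going by the values given here, compound 2 `CCOC(=O)c1cnc(-c2cccs2)nc1NN1C(=O)C=C(C)C1=O` gives 20 nM, and the single change between them, a 500-fold lower number from compound 1 to compound 2 (2.70 log units; beyond the scatter), is the largest step in the set. Compound 3 `CCOC(=O)c1cnc(-c2cccs2)nc1N(C)N1C(=O)C=C(C)C1=O` gives 1000 nM; the change a 50-fold higher number from compound 2 to compound 3 (1.70 log units; beyond the scatter) moves the number well back up. Compound 3 therefore holds the second highest number of the three: its step to compound 1 is beyond the scatter, and its step to compound 2 is the widest gap it has.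

Compound 4 `CCOC(=O)c1cnc(CC)nc1N(C)N1C(=O)C=C(C)C1=O` is not yet measured. It differs from compound 3 by ethyl in place of thiophen-2-yl on an aromatic carbon. This is the same exchange as between compound 1 and compound 2, run in the opposite direction, on a core that already carries the methyl on the nitrogen. Among the compounds with values here, only one measured step bears on it, a 500-fold lower number from compound 1 to compound 2 (2.70 log units; beyond the scatter), and it was large. Reversing it should push the number of compound 4 strongly upward in this assay, so a weaker inhibitor is expected, with the step of a 100-fold higher number from compound 3 to compound 4 (2.00 log units; beyond the scatter) estimated from that precedent. Compound 4 is expected to give about 100000 nM, within a range from 10000 nM to 1000000 nM, and the assay may well report only a limit.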

Compound 4, half-maximal inhibitory concentration: 10000 nM
Compound 4: middle estimate off by 10-fold (1.00 log units), on the high side; low and high end bracket the measured number.
By their numbers in this assay, from the lowest: compound 2; then compound 3; then compounds 1 and 4 (each within the scatter of the next).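

The exchange of thiophen-2-yl for ethyl, on the aromatic carbon between two ring nitrogen atoms, still counts once the nitrogen carries a methyl, with a 10-fold higher number from compound 3 to compound 4 (1.00 log units; beyond the scatter), but its size depends on the core it is made on: the same change on two cores in this assay, a 500-fold lower number (2.70 log units; beyond the scatter) from compound 1 to compound 2 and a 10-fold lower number (1.00 log units; beyond the scatter) from compound 4 to compound 3, 50-fold (1.70 log units) apart, beyond the scatter of two such steps. The methyl on the nitrogen has no fixed cost either, since on the ethyl core it gives no change at the digits printed from compound 1 to compound 4 (within the scatter), whereas on the thiophen-2-yl core it raised the number sharply: the same change on two cores in this assay, a 50-fold higher number (1.70 log units; beyond the scatter) from compound 2 to compound 3 and no change at the digits printed (within the scatter) from compound 1 to compound 4, 50-fold (1.70 log units) apart, beyond the scatter of two such steps. So in these four compounds the two changes do not simply add up, and the benefit of thiophen-2-yl is far greater where the nitrogen keeps its hydrogen.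

The compounds shown leave open whether the gain at this carbon comes from the thiophene ring itself or from any larger group, a question that a phenyl ring or a longer chain such as butyl in the same place could help to settle. They also leave open how a group larger than methyl on the nitrogen, such as ethyl or propyl, would behave on the thiophen-2-yl core.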